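The source may report more compounds than this note shows. Statements on the series, on what has been measured and on what is new or still open speak of the compounds shown alone.

Compound 1 `CCCN(CCC)c1cc(C(F)(F)F)ccc1CNC(=O)C(C)c1ccc(NS(C)(=O)=O)c(F)c1`: 0.3 nM
Compound 2 `CC(C(=O)NCc1ccc(C(F)(F)F)cc1N1CCN(c2ccccc2)CC1)c1ccc(NS(C)(=O)=O)c(F)c1`: 2 nM
Compound 3 `CC(C)CCOc1cc(C(F)(F)F)ccc1CNC(=O)C(C)c1ccc(NS(C)(=O)=O)c(F)c1`: 0.5 nM

Three compounds share one core and differ only in the group on one aromatic carbon of the six-membered ring that carries the trifluoromethyl group. In an assay on CHO cells for antagonist activity at transient receptor potential cation channel subfamily V member 1 (Homo sapiens), read by FLIPR (a lower number here means a stronger inhibitor, a higher number a weaker inhibitor), compound 3 gives 0.5 nM, the second highest of the three numbers; its nearest neighbour is compound 1, and a 1.7-fold higher number from compound 1 to compound 3 (0.22 log units; within the scatter), while the step of a 4.0-fold lower number from compound 2 to compound 3 (0.60 log units; beyond the scatter) lies beyond the scatter.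

Compound 4 `CC(C(=O)NCc1ccc(C(F)(F)F)cc1-c1cccc(F)c1)c1ccc(NS(C)(=O)=O)c(F)c1` carries a new group at that same carbon: 3-fluorophenyl in place of isopentyloxy on an aromatic carbon. Within the data shown here, two measured steps bear on this: a 6.7-fold higher number from compound 1 to compound 2 (0.82 log units; beyond the scatter), where a ring-bearing group replaced an open chain, and a 4.0-fold lower number from compound 2 to compound 3 (0.60 log units; beyond the scatter), going back to a chain. Both say that a ring at this position has so far gone with a weaker inhibitor than a chain, though the ring in compound 2 is much larger than 3-fluorophenyl. A step of this size, upward, is therefore expected: a 2.4-fold higher number from compound 3 to compound 4 (0.38 log units; beyond the scatter). Compound 4 is estimated at 1.2 nM, with a range from 0.3 nM to 5 nM.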

Compound 4, inhibition constant: 1.9 nM
For compound 4 the middle estimate is 1.6-fold (0.20 log units) below the measured one, and the stated range covers the measured number.
By their numbers in this assay, from the lowest: compounds 1 and 3 (each within the scatter of the next); then compounds 4 and 2 (each within the scatter of the next).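

The much smaller 3-fluorophenyl group gives a number that cannot be told apart from that of the larger 4-phenylpiperazin-1-yl group (a 1.1-fold lower number from compound 2 to compound 4 (0.02 log units; within the scatter)), so the size of the ring group makes no visible difference across this pair. Among these compounds, compound 4 also stays clearly apart from both open-chain compounds (a 3.8-fold higher number from compound 3 to compound 4 (0.58 log units; beyond the scatter); a 6.3-fold higher number from compound 1 to compound 4 (0.80 log units; beyond the scatter)), so all four compounds now divide cleanly: the two with a ring in this group give the higher numbers and the two with an open chain give the lower numbers, with no compound going against this split. No measurement available here gives a reason for this split. Still open, as far as these compounds go, is whether the split holds for a plain phenyl or a cyclohexyl group. A morpholine or a shorter chain such as ethoxy could also test it.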